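Swapping the side group on compound 3

This account rests on a few compounds, and the source may have more. Where it says the series, first, only, none or still open, it means among the compounds named here.

Values so far in an ADME assay on cells (Erythrocyte, Homo sapiens), read by spectrophotometry and hemolysis, with a stated time of 24 h (on this read-out higher numbers stand for weaker inhibition and lower numbers for stronger inhibition), are these
compound 1 `C=CCNC(=S)N/N=C\c1ccccc1OCc1ccc2no[n+]([O-])c2c1` gives 139 uM
compound 2 `[O-][n+]1onc2ccc(COc3ccccc3/C=N\NC(=S)Nc3ccccc3)cc21` gives > 200 uM (a limit of the assay, not a number)
compound 3 `CC1(C)[N+]([O-])=c2ccc(COc3ccccc3/C=N\NC(=N)N)cc2=[N+]1[O-]` gives 114 uM

Compound 3 reads 114 uM and compound 1 reads 139 uM and these two values lie within the scatter of each other. Compound 2 reads > 200 uM and that reading is a limit, not a number.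

The next compound is compound 4 `CC1(C)[N+]([O-])=c2ccc(COc3ccccc3/C=N\NC(=S)Nc3ccccc3)cc2=[N+]1[O-]` which keeps the core of compound 3. Among the measured compounds shown here, the change is a group of 9 heavy atoms (7 carbon, 1 nitrogen, 1 sulfur; one six-membered aromatic ring of carbon only) in place of a group of 3 heavy atoms (1 carbon, 2 nitrogen; no ring), on an amine nitrogen and the group that enters is the one compound 2 also carries, though on a different core.

For the measured compounds named here, only one measured step comes close to this change. It is an at least 1.4-fold higher number from compound 1 to compound 2 (0.15 log units; that floor lies within the scatter) and it also brings in a phenyl group, though in place of allyl and on the core of compound 1. That step ends at the limit of > 200 uM in this assay, at which 1 of the 3 values shown sits, so it gives a floor and not a true size.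

It therefore serves only as a rough guide, pointing towards a higher number in this assay for the new compound. The expected step is a 1.6-fold higher number from compound 3 to compound 4 (0.20 log units; within the scatter) and it is an estimate resting on that one comparison. Compound 4 is estimated at 180 uM with an expected range from 90 uM to 350 uM and the assay may report only a limit.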

Compound 4, concentration for 50% inhibition: 66 uM
Compound 4: middle estimate off by 2.7-fold (0.44 log units), on the high side, and the stated range ends above it.
By their numbers in this assay, from the lowest: compounds 4, 3 and 1 (each within the scatter of the next, the first and the last beyond it). At a limit, above all of these: compound 2.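

In this assay, among the compounds shown here, the exchange on the amine nitrogen of compound 3 gives the first step in this set that carries a true size on both sides, rather than a floor set by a limit: a 1.7-fold lower number from compound 3 to compound 4 (0.24 log units; within the scatter). A group of 9 heavy atoms with a six-membered aromatic ring can therefore stand at this place in the shared core, in place of a group of 3 heavy atoms with no ring, without a shift beyond the scatter, and compound 4 gives 66 uM, a real number and not a limit. Compound 2 carries the same entering group on a different core and stays at a limit, not a number: the limit of > 200 uM in this assay, at which 1 of the 4 values shown sits.

From the compounds shown here alone, what remains open is which part of the entering group matters at this place, the phenyl ring or the sulfur-bearing link that joins it to the amine nitrogen. A simple amine or a longer alkyl chain on that link of the core of compound 3 would help to separate these two parts and show whether any change here can move the number beyond the scatter.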